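A few compounds are considered here, and "the series" means these few. Any claim that something is new, unique, unknown or untested is made for them only; others in the source may bear on it.

Measured so far:
compound 1, `COc1cc2c(Oc3ccc(NC(=O)c4cc(-c5ccccc5F)ccn4)cc3F)ccnc2cc1OCCCN1CCCCC1`, 180 nM in a functional assay on MKN-45 cells (Homo sapiens) for cytotoxicity, read by MTT assay, with a stated time of 72 h; a lower number here means a stronger inhibitor, a higher number a weaker inhibitor
compound 2, `COc1cc2c(Oc3ccc(NC(=O)c4cc(-c5ccccc5)ccn4)cc3F)ccnc2cc1OCCCN1CCCCC1`, 270 nM
compound 3, `COc1cc2c(Oc3ccc(NC(=O)c4nccc(-c5ccc(F)cc5)n4)cc3F)ccnc2cc1OCCCN1CCN(C)CC1`, 90 nM

Compounds 1 and 2 share one core and differ in a single place: fluoro in place of hydrogen on an aromatic carbon. That change gave a 1.5-fold lower number from compound 2 to compound 1 (0.18 log units; within the scatter). Compound 3 has a different core; the difference between the two cores is not broken down here. Its value is the lowest of the three, but its gap to compound 1 is within the scatter, so no order between them can be claimed.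

Compound 4, `COc1cc2c(Oc3ccc(NC(=O)c4nccc(-c5ccc(F)cc5F)n4)cc3F)ccnc2cc1OCCCN1CCN(C)CC1`, is compound 3 with one change: fluoro in place of hydrogen on an aromatic carbon. This is the same kind of change as from compound 2 to compound 1, not the same: in compound 4 the new fluoro sits ortho to a large group and meta to a fluoro group (1 heavy atom), whereas in compound 1 it sits only ortho to a large group. Since the earlier step was small, a step of similar size is expected, a 1.3-fold lower number from compound 3 to compound 4 (0.11 log units; within the scatter), resting on compound 3 at 90 nM. Compound 4 is therefore estimated at 70 nM, most likely between 30 nM and 180 nM.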

Compound 4, half-maximal inhibitory concentration: 440 nM
Compound 4: middle estimate off by 6.3-fold (0.80 log units), on the low side; the whole stated range lies below it.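

In this assay, going from 4-fluorophenyl to 2,4-difluorophenyl gave a 4.9-fold higher number from compound 3 to compound 4 (0.69 log units; beyond the scatter), so here the added fluoro came with a weaker inhibitor. The earlier step therefore did not predict this one, and in this series the same kind of change cannot simply be carried from one core to the other: the same change on two cores in this assay, a 1.5-fold lower number (0.18 log units; within the scatter) from compound 2 to compound 1 and a 4.9-fold higher number (0.69 log units; beyond the scatter) from compound 3 to compound 4, 7.3-fold (0.87 log units) apart, beyond the scatter of two such steps. This does not show what drives the difference, since the two steps differ in their cores and also in the surroundings of the new fluoro, which in compound 4 sits ortho to a large group and meta to a fluoro group, while in compound 1 it sits only ortho to a large group.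

The compounds shown leave open whether this rise belongs to fluoro itself or would also appear with another group in the same place, such as chloro or methyl. They also leave open how a 2,4-difluorophenyl group would behave on the core of compound 1.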